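Hydroxy to amino on the pendant ring of compound 2

The compounds below may be only part of what the source reports. "The series", "measured", "known", "first", "only" and "open" are said of these compounds alone.

In a functional assay on U2OS cells (Homo sapiens) for cytotoxicity, read by MTT assay, with a stated time of 48 h (on this read-out higher numbers stand for weaker inhibition and lower numbers for stronger inhibition), compound 1 `Fc1cccc(Nc2nc(-c3cccc(F)c3)nc3ccc(F)cc23)c1` gives 49600 nM and compound 2 `Oc1ccccc1Nc1nc(-c2cccc(F)c2)nc2ccc(F)cc12` gives 41400 nM. The two numbers sit within the scatter of each other, so compound 2 is not distinguished from compound 1. Compound 3 `Nc1ccccc1Nc1nc(-c2cccc(F)c2)nc2ccc(F)cc12` differs from compound 2 by amino in place of hydroxy on an aromatic carbon. Among the measured compounds shown here, the only measured step, a 1.2-fold lower number from compound 1 to compound 2 (0.08 log units; within the scatter), changes the same pendant ring and stays within the scatter, so no step beyond the scatter is expected in this assay. Compound 3 is therefore expected to give 40000 nM (range 15000 nM to 100000 nM), an estimated step of a 1.0-fold lower number from compound 2 to compound 3 (0.01 log units; within the scatter).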

Compound 3, half-maximal inhibitory concentration: 37900 nM
Compound 3: the middle estimate sits 1.1-fold (0.02 log units) above what was measured; measured number inside the range.
By their numbers in this assay, from the lowest: compounds 3, 2 and 1 (each within the scatter of the next).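

In this assay, amino in place of hydroxy on the aromatic carbon ortho to a large group gives (a 1.1-fold lower number from compound 2 to compound 3 (0.04 log units; within the scatter)), and 2-aminophenyl in place of 3-fluorophenyl on the nitrogen gives (a 1.3-fold lower number from compound 1 to compound 3 (0.12 log units; within the scatter)). Hydroxy and amino at this position are therefore not told apart on this read-out, and the three pendant rings shown all lie within the scatter of one another. No evidence bears on this result. Still open, from the compounds shown here alone, is whether a carboxylic acid or a methoxy group at this position would give a step beyond the scatter.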